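A few compounds are considered here, and "the series" means these few. Any claim that something is new, unique, unknown or untested is made for them only; others in the source may bear on it.

Measured so far in a functional assay on HeLa cells (Homo sapiens) for cytotoxicity, read by CCK-8 assay; on this read-out lower numbers stand for stronger inhibition and higher numbers for weaker inhibition:
- compound 1, `Oc1ccc(-c2cc(-c3cccs3)cc(-c3ccccc3O)n2)cc1`, gives > 50000 nM; this is a limit of the assay, not a number (the limit of > 50000 nM in this assay, at which 1 of the 2 values shown sits).
- compound 2, `Oc1ccc(-c2cc(-c3cccs3)cc(-c3cccc(O)c3)n2)cc1`, gives 4140 nM, the only number shown.

Compound 3, `Oc1ccc(-c2cc(-c3cccs3)cc(-c3ccc(O)cc3)n2)cc1`, differs from compound 2 by 4-hydroxyphenyl in place of 3-hydroxyphenyl on an aromatic carbon. Going by the values given here, the only measured step, an at least 12-fold lower number from compound 1 to compound 2 (1.08 log units; beyond the scatter), also moved the hydroxyl on the same ring and was large, but it does not tell how the 4-hydroxyphenyl compares with the 3-hydroxyphenyl. In this assay no step beyond the scatter is expected, direction open. Compound 3 is estimated at 4000 nM, range 1000 nM to 16000 nM. The expected step is a 1.0-fold lower number from compound 2 to compound 3 (0.01 log units; within the scatter).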

Compound 3, half-maximal inhibitory concentration: > 50000 nM
Compound 3: no number, only a limit (the forecaster's own chance of this, stated with the estimate: 10%); middle value at least 12-fold (1.09 log units) away from the limit.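

In this assay, the change from 3-hydroxyphenyl to 4-hydroxyphenyl gives an at least 12-fold higher number from compound 2 to compound 3 (1.08 log units; beyond the scatter), so this place next to the ring nitrogen tells apart two groups with the same atoms. Of the three hydroxyphenyl groups shown here, only 3-hydroxyphenyl, in compound 2, gives a number. Compound 3, like compound 1, gives a limit and not a number, and the step between these two cannot be read: the limit of > 50000 nM in this assay, at which 2 of the 3 values shown sit.

Still open, going by these compounds, is whether an amine or a carboxylic acid in place of the hydroxyl of 3-hydroxyphenyl would keep the read-out of compound 2.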